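The source may report more compounds than this note shows. Statements on the series, on what has been measured and on what is new or still open speak of the compounds shown alone.

The measured compounds and their values:

compound 1, `Nc1nc(N)c(CCCN(Cc2ccc(NC(CCC(=O)O)C(=O)O)cc2)c2cc(F)cc(F)c2[N+](=O)[O-])c(O)n1`: > 100000 nM
compound 2, `COC(=O)c1ccc(CN(CCCc2c(N)nc(N)nc2O)c2cc(F)c(F)cc2[N+](=O)[O-])cc1`: 59000 nM
compound 3, `CC(C)(C)OC(=O)CCC(Nc1ccc(CN(CCCc2c(N)nc(N)nc2O)c2cc(F)cc(F)c2[N+](=O)[O-])cc1)C(=O)OC(C)(C)C`: 13000 nM

All three were tested in a functional assay on CCRF-CEM cells (Homo sapiens) for cytotoxicity, in the absence of a further agent; a lower number here means a stronger inhibitor, a higher number a weaker inhibitor. For compound 1 the result is a limit of the assay rather than a number, given as > 100000 nM; this is the case described by the limit of > 100000 nM in this assay, at which 1 of the 3 values shown sits. Compound 2, with its methyl ester, gives 59000 nM in this assay. Compound 3, carrying the two tert-butyl esters, gives 13000 nM in this assay and so stands lowest of the two numbers shown, with compound 2 the nearest at a higher number, a gap beyond the usual scatter.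

The next compound, compound 4, `CC(C)(C)OC(=O)CCC(Nc1ccc(CN(CCCc2c(N)nc(N)nc2O)c2cc(F)c(F)cc2[N+](=O)[O-])cc1)C(=O)OC(C)(C)C`, has not yet been measured in this assay. It differs from compound 3 only in the arrangement of the same atoms: 4,5-difluoro-2-nitrophenyl in place of 3,5-difluoro-2-nitrophenyl on an amine nitrogen. The change is a shift of fluorine placement on the same aromatic ring, with everything else held constant.

Among the compounds with values here, no step between two measured compounds isolates this kind of change, so there is no direct precedent in these data. The expectation is a small step in this assay, in either direction or none beyond the scatter, estimated as a 1.2-fold higher number from compound 3 to compound 4 (0.06 log units; within the scatter). Compound 4 is therefore expected to give 15000 nM in this assay, with a likely range from 5000 nM to 45000 nM.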

Compound 4, half-maximal inhibitory concentration: 4800 nM
For compound 4 the middle estimate is 3.1-fold (0.49 log units) above the measured one, outside the stated range (below it).
By their numbers in this assay, from the lowest: compound 4; then compound 3; then compound 2. At a limit, above all of these: compound 1.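

Within the data shown here, the shift from 3,5-difluoro-2-nitrophenyl to 4,5-difluoro-2-nitrophenyl on an amine nitrogen gives the first reading of fluorine placement on this ring in this assay, and the result is a 2.7-fold lower number from compound 3 to compound 4 (0.43 log units; beyond the scatter), a modest step but one beyond the usual scatter. Both groups hold the same atoms, so with the two tert-butyl esters in place, the arrangement of the two fluorines on this ring is enough on its own to move the number in this assay. No measured property among the data shown bears on this step, and its origin stays unexplained.

Whether the same shift of fluorine would move the number when the two tert-butyl esters give way to free carboxylic acids or to a methyl ester stays open, as the compounds shown contain no such matched pair. Also open, from the compounds shown here alone, is how a ring with a single fluorine, a chlorine in place of a fluorine, an amine in place of the nitro group, or a longer chain on the amine nitrogen would compare in this assay.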